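This account rests on a few compounds, and the source may have more. Where it says the series, first, only, none or still open, it means among the compounds named here.

In a functional assay on HT-29 cells (Homo sapiens) for antiproliferative activity, read by MTT assay, with a stated time of 72 h (on this read-out lower numbers stand for stronger inhibition and higher numbers for weaker inhibition), compound 1 `CCCCCn1ccnc1-c1cc(OC)c(OC)c(OC)c1` gives 60100 nM and compound 2 `COc1cc(-c2nccn2-c2cccc(C)c2)cc(OC)c1OC` gives 14600 nM, the lower of the two numbers. For the measured compounds named here, the only measured step, a 4.1-fold lower number from compound 1 to compound 2 (0.61 log units; beyond the scatter), is 3-methylphenyl in place of pentyl on an aromatic nitrogen, so it does not test the next change. Compound 3 `COc1cc(-c2nccn2-c2cccc([N+](=O)[O-])c2)cc(OC)c1OC` has nitro in place of methyl on an aromatic carbon. Starting from compound 2 at 14600 nM, with no measured step of this kind, no shift beyond the scatter is expected in this assay. Compound 3 is estimated at 12000 nM, with a range of 3000 nM to 45000 nM. This estimate means an expected 1.2-fold lower number from compound 2 to compound 3 (0.09 log units; within the scatter).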

Compound 3, half-maximal inhibitory concentration: > 100000 nM
Compound 3: a limit, no number; the forecaster's own chance of this, stated with the estimate: 10%; middle value at least 8.3-fold (0.92 log units) away from the limit.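

In this assay, nitro in place of methyl on the six-membered aromatic ring, meta to a large group, gives an at least 6.8-fold higher number from compound 2 to compound 3 (0.83 log units; beyond the scatter). The earlier step exchanged the whole group on the aromatic nitrogen, whereas this one shows that a single group on that ring can move the read-out beyond the scatter. The value of compound 3 is a limit and not a number: the limit of > 100000 nM in this assay, at which 1 of the 3 values shown sits.

The compounds shown leave open where an amine or a chlorine atom at this place would fall relative to methyl and nitro. They also leave open what in the nitro group lies behind the step.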